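Dimethylamino for Methoxy on a Shared Core

This account rests on a few compounds, and the source may have more. Where it says the series, first, only, none or still open, it means among the compounds named here.

Of the compounds shown here, three have been measured in a functional assay for inhibition, with Homo sapiens as the target; a higher number here means a weaker inhibitor, a lower number a stronger inhibitor. Compound 2 `COc1ccc(Nc2nccc(-c3cccs3)n2)cc1` gives 3900 nM, the second highest of the three numbers. Its nearest neighbour is compound 1 `CNc1ccc(Nc2nccc(-c3cccnc3)n2)cc1`, which gives 2100 nM; the two lie within the usual scatter of each other. Far away stands compound 3 `O=C(O)c1cc(=O)c2c(OCC(COc3cccc4oc(C(=O)O)cc(=O)c34)Oc3nccc(-c4ccccn4)n3)cccc2o1`, which gives 1000000 nM, a gap well beyond the scatter. Compound 4 `CN(C)c1ccc(Nc2nccc(-c3cccs3)n2)cc1` has not yet been tested. It differs from compound 2 in one place: dimethylamino in place of methoxy on an aromatic carbon. Within the data shown here, no measured pair shows this exact change, so the expectation rests on the closeness of compound 1, bearing methylamino, to compound 2. The expected step is a 1.4-fold lower number from compound 2 to compound 4 (0.14 log units; within the scatter), which stays within the scatter. Compound 4 is estimated at 2800 nM, within 900 nM to 9000 nM.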

Compound 4, half-maximal inhibitory concentration: 900 nM
Estimate against measurement, compound 4: 3.1-fold (0.49 log units) above; low and high end bracket the measured number.
By their numbers in this assay, from the lowest: compound 4; then compounds 1 and 2 (each within the scatter of the next); then compound 3.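

In this assay, dimethylamino in place of methoxy on this aromatic carbon gives a 4.3-fold lower number from compound 2 to compound 4 (0.64 log units; beyond the scatter), so the group at this position can shift the number beyond the scatter. The two groups have the same counts of hydrogen-bond donors and acceptors, so those counts do not separate them. Nothing measured here accounts for the step.

As far as these compounds go, whether diethylamino or a plain amino group at this place would lower the number further remains open. So does whether the same change would give a similar step on the core of compound 1.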